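Sulfonamide polyamines: butyl extension carried onto a shorter core

The source may report more compounds than this note shows. Statements on the series, on what has been measured and on what is new or still open speak of the compounds shown alone.

Measured so far:
Compound 1, `CCCCCCCCS(=O)(=O)NCCCNCCCNCCCCNCCCN`, in a functional assay on HEK293 cells (Homo sapiens) for inhibition (a lower number here means a stronger inhibitor, a higher number a weaker inhibitor), gives 816 nM.
Compound 2, `CCCCCCCCCCCCS(=O)(=O)NCCCNCCCNCCCCNCCCN`, in this assay gives 190 nM.
Compound 3, `CCCCCCCCS(=O)(=O)NCCNCCCNCCN`, in this assay gives 13800 nM.

Compound 1 and compound 2 share a core and differ by butyl in place of hydrogen on a saturated chain carbon, eight bonds along the chain from a sulfonyl sulfur. That change gave a 4.3-fold lower number from compound 1 to compound 2 (0.63 log units; beyond the scatter).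

Compound 3 carries a shorter core; how it differs from the core of compound 1 is not broken down here. Its number is the highest of the three.

Compound 4, `CCCCCCCCCCCCS(=O)(=O)NCCNCCCNCCN`, differs from compound 3 by butyl in place of hydrogen on a saturated chain carbon, eight bonds along the chain from a sulfonyl sulfur. The place is described in the same words as for the first pair, so this is the same change on the other core.

The expected step is a 4.3-fold lower number from compound 3 to compound 4 (0.63 log units; beyond the scatter), resting on a 4.3-fold lower number from compound 1 to compound 2 (0.63 log units; beyond the scatter). Whether the shorter core carries the gain equally is not known from these three compounds.

Compound 4 is therefore estimated at 3200 nM, with a range of 1200 nM to 9000 nM.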

Compound 4, half-maximal inhibitory concentration: 686 nM
Compound 4: the middle estimate sits 4.7-fold (0.67 log units) above what was measured; measured number outside the range, below it.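

In this assay, butyl in place of hydrogen gives a 20-fold lower number from compound 3 to compound 4 (1.30 log units; beyond the scatter) and so lowers the number on the shorter core as well. The two steps do not match in size: the same change on two cores in this assay, a 4.3-fold lower number (0.63 log units; beyond the scatter) from compound 1 to compound 2 and a 20-fold lower number (1.30 log units; beyond the scatter) from compound 3 to compound 4, 4.7-fold (0.67 log units) apart, beyond the scatter of two such steps. The change therefore carries from one core to the other in direction only, and two pairs do not show what in the cores sets the size of the step or how it would run on a third core.

Open, going by these compounds, is whether a longer chain or a phenyl group in place of the butyl extension would give the same gap between the two cores. Also open, on these data alone, is whether a carboxamide in place of the sulfonyl group would do so.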